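Swapping the Nitrile for Bromine in Compound 3

This account rests on a few compounds, and the source may have more. Where it says the series, first, only, none or still open, it means among the compounds named here.

Of the compounds shown here, two have been measured in an in vitro functional assay on cells for antagonist activity at metabotropic glutamate receptor 1 (Rattus norvegicus), read by inositol phosphate accumulation; a lower number here means a stronger inhibitor, a higher number a weaker inhibitor. Compound 1 `CC1(C)CC(=O)c2cc(C#N)c(N3CCN(c4ccccc4)CC3)nc2C1` gives 130 nM. Compound 2 `CC1(C)CC(=O)c2cc(C#N)c(N3CCN(c4ccc(F)cc4)CC3)nc2C1`, which carries a fluoro in place of hydrogen on the distal aromatic ring, gives 160 nM. Within the data shown here, the only step known so far, a 1.2-fold higher number from compound 1 to compound 2 (0.09 log units; within the scatter), leaves the two compounds indistinguishable within the usual scatter, so compound 2 stands at the higher of two numbers that cannot be told apart.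

Compound 3 `CC1(C)CC(=O)c2cc(Br)c(N3CCN(c4ccc(F)cc4)CC3)nc2C1` has not yet been measured. It differs from compound 2 in one place: bromo in place of cyano on an aromatic carbon. Among the measured compounds shown here, the step from compound 1 to compound 2 touched a different ring and does not bear directly on this change; no measured pair tells what happens when the cyano on the fused core is exchanged for bromo. With nothing to anchor the direction, the estimate for compound 3 in this assay stays close to compound 2, allowing a wide range in either direction. The expected step is a 1.6-fold higher number from compound 2 to compound 3 (0.19 log units; within the scatter). Compound 3 is therefore estimated at 250 nM, between 80 nM and 800 nM.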

Compound 3, half-maximal inhibitory concentration: <= 1000 nM
Compound 3 gave a limit, no number; the forecaster's own chance of this, stated with the estimate: 5%; the middle value lies beyond the limit too.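

Compound 3 gave a limit and not a number in this assay, so the step from compound 2 to compound 3 cannot be read, and the only thing to go on is: the limit of <= 1000 nM in this assay, at which 1 of the 3 values shown sits.

The compounds shown leave open whether bromo in place of cyano on this aromatic carbon gives a stronger inhibitor, a weaker one, or neither.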